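Working notes on solubility in a three-compound series

The source may hold more compounds than are shown below. What is called first, only, known or untested is meant among the compounds shown, and "the series" means these compounds.

Measured so far:
compound 1 `COc1ccc(F)cc1CNCCCNc1ccnc2cc(Cc3ccc(C#N)cc3)ccc12` — 4200 nM
compound 2 `COc1ccc(-c2ccc3c(NCCCNCc4ccco4)ccnc3c2)cc1` — 32000 nM

In a physicochemical assay for solubility, with a stated time of 18 h, at pH 7.4 (on this read-out lower numbers stand for lower solubility and higher numbers for higher solubility), compound 1 gives 4200 nM, the lower of the two numbers measured. Compound 2 gives 32000 nM in this assay, a higher figure that lies beyond the scatter. Going by the values given here, the two measured compounds differ in more than one place, so no single-site step between them can be read off.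

Compound 3 `COc1ccc(F)cc1CNCCCNc1ccnc2cc(CC(C)C)ccc12` is not yet measured and differs from compound 1 in one place: isopropyl in place of 4-cyanophenyl on a saturated chain carbon bound to an aromatic carbon. Among the compounds with values here, nothing among the measured compounds isolates this change, so the expectation rests on the value of compound 1 alone. In this assay the expected step is small and upward, probably not beyond the scatter: a 1.7-fold higher number from compound 1 to compound 3 (0.22 log units; within the scatter). In this assay compound 3 is expected at 7000 nM, with a range from 2500 nM to 20000 nM.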

Compound 3, solubility: 4200 nM
Compound 3: middle estimate off by 1.7-fold (0.22 log units), on the high side, and the stated range covers the measured number.
By their numbers in this assay, from the lowest: compounds 1 and 3 (each within the scatter of the next); then compound 2.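

In this assay, going by these compounds alone, isopropyl in place of 4-cyanophenyl on a saturated chain carbon bound to an aromatic carbon gives no change at the digits printed from compound 1 to compound 3 (within the scatter), the first single-site step. At this position, the read-out therefore does not separate a group with one six-membered aromatic ring, a triple bond and a hydrogen-bond acceptor from one with no ring and no hydrogen-bond acceptor. No measurement at hand bears on why the two compounds read alike.

On these data alone, whether other groups at this position, such as an amine or a carboxylic acid, would also leave the read-out unmoved remains open. Compound 2 differs from both compound 1 and compound 3 in more than one place, so no single-site step to it can be read, and nothing shown assigns its value to any one site.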